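The source may report more compounds than this note shows. Statements on the series, on what has been measured and on what is new or still open speak of the compounds shown alone.

Of the compounds shown here, three have been tested in a functional assay on KBVIN cells (Homo sapiens) for antiproliferative activity, read by sulforhodamine B assay, with a stated time of 72 h; on this read-out lower numbers stand for stronger inhibition of growth and higher numbers for weaker inhibition of growth. Compound 1 `Cc1cc(=O)oc2cc(SCc3cccc(C#N)c3)ccc12` and compound 2 `COc1cc(CSc2ccc3c(C)cc(=O)oc3c2)c([N+](=O)[O-])cc1OC` share the same core, while compound 3 `CCc1cc(=O)c2ccc(OCc3cccc(C)c3)c(C)c2o1` is built on a different one. In this assay compound 1 reaches only a limit of the assay and no number, > 32500 nM. In this assay compound 2 likewise gives only a limit, > 25800 nM. Among the measured compounds shown here, compound 3 is the one compound with a measured number: in this assay compound 3 gives 24900 nM, so it stands as the sole number among the three. For the measured compounds named here, no pair of measured compounds differs in just one place, so no measured step is available to guide the next change.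

Compound 4 `CCc1cc(=O)c2ccc(OCc3cccc(C#N)c3)c(C)c2o1` is compound 3 with one change: cyano in place of methyl on an aromatic carbon. Going by the values given here, no measured step shows the effect of this swap, and compound 3 is already a weak inhibitor, so the expected step is none beyond the scatter, a 1.1-fold higher number from compound 3 to compound 4 (0.05 log units; within the scatter). Compound 4 is therefore expected to give about 28000 nM, within a range of 12000 nM to 70000 nM, with a real chance that only a limit is reported.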

Compound 4, concentration for 50% growth inhibition: > 31300 nM
Compound 4: no number, only a limit; the forecaster's own chance of this, stated with the estimate: 50%; at least 1.1-fold (0.04 log units) between middle value and limit.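

In this assay, among the compounds shown here, the swap of 3-methylphenyl for 3-cyanophenyl gives the first step that can be read between two compounds differing in one place: an at least 1.2-fold higher number from compound 3 to compound 4 (0.09 log units; that floor lies within the scatter). The floor of that step lies within the usual scatter, so this change on this aromatic carbon brings no gain in growth inhibition, and the data cannot say whether it brings a real loss. From the compounds shown here alone, the size of the step stays open because compound 4 gives no number, only a limit of the assay: the limit of > 31300 nM in this assay, at which 1 of the 4 values shown sits.

The compounds shown leave open how a different kind of group on this same aromatic carbon, such as an amine or a carboxylic acid, would behave in this assay, since methyl and cyano are the only two groups compared here. They also leave open whether a change elsewhere on the core of compound 3, such as a longer chain in place of the ethyl group, would move growth inhibition more than this swap did.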